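Compound 2 to compound 3: 4-bromophenyl on the amide

A few compounds are considered here, and "the series" means these few. Any claim that something is new, unique, unknown or untested is made for them only; others in the source may bear on it.

Measured so far in a functional assay on MDA-MB-231 cells (Homo sapiens) for cytotoxicity, read by MTT assay, with a stated time of 72 h (a lower number here means a stronger inhibitor, a higher number a weaker inhibitor), as follows
compound 1 `O=C(CN1CCN(c2nnc(Cc3ccncc3)c3ccccc23)CC1)Nc1ccc(Br)cc1` gives 19 nM
compound 2 `O=C(CN1CCN(c2nnc(Cc3ccccc3)c3ccccc23)CC1)Nc1ccc(F)c(F)c1` gives 2750 nM

Of these two numbers, compound 2 (2750 nM) holds the higher and is thus the weaker inhibitor, and its gap to compound 1 lies beyond the scatter. Going by the values given here, the step to follow leads to compound 3 (`O=C(CN1CCN(c2nnc(Cc3ccccc3)c3ccccc23)CC1)Nc1ccc(Br)cc1`) with 4-bromophenyl in place of 3,4-difluorophenyl on an amide-type nitrogen as the only change.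

Among the compounds with values here, no measured pair differs in one place only, so the size of this step cannot be read directly from the data. Within the data shown here, the one measured compound carrying 4-bromophenyl on that nitrogen is compound 1 (19 nM) but the gap from compound 2 need not belong to this change alone. A move to a lower number is therefore expected, beyond the scatter yet smaller than that whole gap. The expected step is an 11-fold lower number from compound 2 to compound 3 (1.04 log units; beyond the scatter) in this assay as a rough estimate. Estimated for compound 3 is 250 nM with 40 nM to 1800 nM as the expected range.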

Compound 3, half-maximal inhibitory concentration: 12400 nM
The estimate for compound 3 lay 50-fold (1.70 log units) below the measured number, and the stated range ends below it.
By their numbers in this assay, from the lowest: compound 1; then compound 2; then compound 3.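

Working notes: in this assay, on the background with phenyl on the saturated chain carbon, 4-bromophenyl in place of 3,4-difluorophenyl on the amide-type nitrogen gives a 4.5-fold higher number from compound 2 to compound 3 (0.65 log units; beyond the scatter), a modest move toward weaker inhibition. The 4-bromophenyl group therefore brings no gain over 3,4-difluorophenyl in this pair, and it does not by itself go with a low number in this series. The large change lies at the other place: phenyl in place of pyridin-4-yl on the saturated chain carbon, with 4-bromophenyl held constant, gives a 650-fold higher number from compound 1 to compound 3 (2.81 log units; beyond the scatter), so in this pair the strong inhibition depends on the pyridin-4-yl group, and no measurement at hand gives a reason for either step.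

From the compounds shown here alone, it remains open whether pyridin-4-yl has a comparable influence when 3,4-difluorophenyl sits on the amide-type nitrogen, and thus whether the two places act separately or together. Also open, going by these compounds, is how other groups on that saturated chain carbon, such as a cyclohexyl group or a carboxylic acid, would compare with phenyl and pyridin-4-yl.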